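A few compounds are considered here, and "the series" means these few. Any claim that something is new, unique, unknown or untested is made for them only; others in the source may bear on it.

For the measured compounds named here, in a functional assay (Left cardiac atrium, Cavia porcellus), with a stated time of 30 min (on this read-out lower numbers stand for an effect already at smaller amounts and higher numbers for an effect only at larger amounts of compound), compound 1 `CC1=CSC(OC(C)C)(c2ccccc2)c2noc(=O)n21` stands at 1190 nM on the only two numbers available so far, and compound 2 `CC1=CSC(OCC2CCCCC2)(c2ccccc2)c2noc(=O)n21` stands at 870 nM within the scatter of it. Compound 2 carries cyclohexylmethyl in place of isopropyl on an oxygen on a saturated carbon, and the measured step is a 1.4-fold lower number from compound 1 to compound 2 (0.14 log units; within the scatter) for that exchange. Compound 3 `COc1cccc(C2(OC(C)C)SC=C(C)n3c2noc3=O)c1` keeps the isopropyl of compound 1 and changes elsewhere, with methoxy in place of hydrogen on an aromatic carbon, meta to a large group. The counted difference is methoxy in place of hydrogen on an aromatic carbon against compound 1. Going by the values given here, the single measured step bears on this change only loosely, as it sits at another place on the shared core. Among the compounds with values here, no measured compound carries a substituent on that aromatic ring, so the direct evidence is missing. No step beyond the scatter is therefore expected in this assay and neither direction is favoured, though the range has to stay wide. The expected step is a 1.1-fold lower number from compound 1 to compound 3 (0.03 log units; within the scatter) on this estimate. Compound 3 is estimated at 1100 nM with an expected range of 350 nM to 3500 nM in this read-out.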

Compound 3, half-maximal effective concentration: 64 nM
Compound 3: the middle estimate sits 17-fold (1.24 log units) above what was measured, outside the stated range (below it).
By their numbers in this assay, from the lowest: compound 3; then compounds 2 and 1 (each within the scatter of the next).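

For the compounds shown here, the aromatic ring of the shared core is the first place where a single exchange moves the number in this assay beyond the scatter. Methoxy in place of hydrogen on an aromatic carbon, meta to a large group, gives a 19-fold lower number from compound 1 to compound 3 (1.27 log units; beyond the scatter), whereas the only earlier exchange, cyclohexylmethyl in place of isopropyl on an oxygen on a saturated carbon, gives a 1.4-fold lower number from compound 1 to compound 2 (0.14 log units; within the scatter), so the substituent on that oxygen and the substituent on the ring do not carry the same weight among these compounds. Nothing available gives a reason for the size of the methoxy step.

As far as these compounds go, whether this step belongs to methoxy itself or to any group at this place stays open, since a hydroxyl, a fluorine or an amine on the same carbon would separate the two readings. From the compounds shown here alone, it is equally open whether methoxy would give a step of similar size with cyclohexylmethyl on the oxygen, as in compound 2, or whether the step would survive at another carbon of the ring.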